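Extending the piperidine side chain with a methanesulfonamide

The compounds below may be only part of what the source reports. "The series", "measured", "known", "first", "only" and "open" are said of these compounds alone.

Of the compounds shown here, two sharing one core have been measured in a functional assay for antagonist activity at 5-hydroxytryptamine receptor 4 (Rattus norvegicus); a lower number here means a less potent compound, a higher number a more potent compound, by a factor of ten per unit of this negative logarithm. Compound 1 `COc1cc(COc2cc(N)c(Cl)cc2C(=O)CCCCN2CCC(OC)CC2)cc(OC)c1` gives 8.4 in this assay. Compound 2 `CCCCCN1CCC(CCC(=O)c2cc(Cl)c(N)cc2OCc2cc(OC)cc(OC)c2)CC1` gives 9.1 in this assay, the higher of the two numbers, with a step of a number 0.70 log units higher from compound 1 to compound 2 (beyond the scatter) that exchanges the linker between the carbonyl and the amine nitrogen in the ring. Compound 3 `COc1cc(COc2cc(N)c(Cl)cc2C(=O)CCC2CCN(CCCNS(C)(=O)=O)CC2)cc(OC)c1` is not yet measured. It differs from compound 2 by methanesulfonamido in place of ethyl on a saturated chain carbon, three bonds along the chain from an amine nitrogen in a ring. For the measured compounds named here, no measured step touches this end of the molecule: the one step available, from compound 1 to compound 2, alters the linker rather than the substituent on the ring nitrogen, so it bears on the change only by showing that the region around the amine nitrogen in the ring tolerates rearrangement. Compound 3 is therefore expected to keep a value near that of compound 2, with an estimated step of a number 0.10 log units lower from compound 2 to compound 3 (within the scatter) that is not expected to exceed the scatter in either direction. The estimate for compound 3 in this assay is 9, ranging from 8.3 to 9.7.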

Compound 3, negative logarithm of the antagonist equilibrium constant: 8.8
The estimate for compound 3 lay 0.20 log units above the measured number; low and high end bracket the measured number.
By their numbers in this assay, from the lowest: compound 1; then compounds 3 and 2 (each within the scatter of the next).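

In this assay, for the compounds shown here, the change gives a number 0.30 log units lower from compound 2 to compound 3 (within the scatter), and this is the first reading at this end of the molecule, since the earlier step altered only the linker. Cut one bond further out, the change is pentyl to 3-(methanesulfonamido)propyl, so a purely carbon chain on the ring nitrogen gives way to one ending in a group with 1 hydrogen-bond donor and 2 hydrogen-bond acceptors, and this read-out does not separate compound 2 from compound 3. Nothing shown accounts for this agreement between two such different substituents, and this pair alone cannot give a reason for it.

As far as these compounds go, the finding rests on a single pair, so it remains open whether a shorter or longer chain carrying the methanesulfonamide, or a chain ending in a carboxylic acid, an amine or a simple amide, would also stay within the scatter of compound 2. From the compounds shown here alone, it is also open whether the 3-(methanesulfonamido)propyl group would read the same way on the linker of compound 1.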